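Swapping the Aryl Substituent of Compound 3

The source may hold more compounds than are shown below. What is called first, only, known or untested is meant among the compounds shown, and "the series" means these compounds.

Compound 1 `CC(C)c1c(C(=O)NCc2ccccc2)nn(-c2ccc(F)cc2)c1OC[C@@H](O)C[C@@H](O)CC(=O)O`: 3.8 nM
Compound 2 `CCN(Cc1ccccc1)C(=O)c1nn(-c2ccc(F)cc2)c(OC[C@@H](O)C[C@@H](O)CC(=O)O)c1C(C)C`: 14 nM
Compound 3 `Cc1ccc(CN(C)C(=O)c2nn(-c3ccc(F)cc3)c(OC[C@@H](O)C[C@@H](O)CC(=O)O)c2C(C)C)cc1`: 37 nM

In an assay on microsomes from liver for inhibition of 3-hydroxy-3-methylglutaryl-coenzyme A reductase (Rattus norvegicus) (on this read-out lower numbers stand for stronger inhibition and higher numbers for weaker inhibition), compound 3 stands at the highest number of the three: a 2.6-fold higher number from compound 2 to compound 3 (0.42 log units; beyond the scatter) and a 9.7-fold higher number from compound 1 to compound 3 (0.99 log units; beyond the scatter). Compound 4 `CC(C)c1c(C(=O)N(C)Cc2cccc(Cl)c2)nn(-c2ccc(F)cc2)c1OC[C@@H](O)C[C@@H](O)CC(=O)O` differs from compound 3 by 3-chlorophenyl in place of 4-methylphenyl on a saturated chain carbon bound to an amide-type nitrogen. Within the data shown here, none of the measured steps touches that ring: a 3.7-fold higher number from compound 1 to compound 2 (0.57 log units; beyond the scatter), a 9.7-fold higher number from compound 1 to compound 3 (0.99 log units; beyond the scatter) and a 2.6-fold higher number from compound 2 to compound 3 (0.42 log units; beyond the scatter) all concern the amide-type nitrogen and the groups on it, so they give no direct guidance on this change. With nothing to point either way, a step within the scatter is expected for compound 4, which is estimated at 37 nM (range 15 nM to 90 nM). That estimate means no change at the digits printed from compound 3 to compound 4 (within the scatter) is expected.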

Compound 4, half-maximal inhibitory concentration: 8.3 nM
Compound 4: the middle estimate sits 4.5-fold (0.65 log units) above what was measured; the whole stated range lies above it.
By their numbers in this assay, from the lowest: compound 1; then compounds 4 and 2 (each within the scatter of the next); then compound 3.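

In this assay, among these compounds, the ring on this saturated chain carbon proves to matter: 3-chlorophenyl in place of 4-methylphenyl gives a 4.5-fold lower number from compound 3 to compound 4 (0.65 log units; beyond the scatter), something no earlier step could show. The (3-chlorobenzyl)(methyl)amino group stays level with benzyl(ethyl)amino, at a 1.7-fold lower number from compound 2 to compound 4 (0.23 log units; within the scatter), but still falls short of benzylamino, at a 2.2-fold higher number from compound 1 to compound 4 (0.34 log units; beyond the scatter). No measurement shown offers an explanation for these steps.

Going by these compounds, two things change at once in this swap, so it remains open whether the chlorine or its place on the ring carries the step. The 4-chlorophenyl and 3-methylphenyl groups would separate the two.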